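The compounds below may be only part of what the source reports. "The series", "measured", "known", "first", "only" and "open" are said of these compounds alone.

Compound 1 `CN1C(=O)S/C(=C\C2=Cc3ccccc3OC2)C1=O` carries a methyl on the amide-type nitrogen of its ring. In a functional assay on K562 cells (Homo sapiens) for antiproliferative activity, read by MTT assay, with a stated time of 72 h (on this read-out lower numbers stand for stronger inhibition and higher numbers for weaker inhibition), compound 1 gives > 100000 nM, which is a limit of the assay and not a number. Compound 2 `CCN1C(=O)S/C(=C\C2=Cc3ccccc3OC2)C1=O` differs from compound 1 only by methyl in place of hydrogen on a saturated chain carbon bound to an amide-type nitrogen in a ring. In this assay compound 2 gives > 200000 nM, again a limit of the assay. The step that the two limits leave unreadable from compound 1 to compound 2 therefore cannot be read in size, since both ends sit at limits, the limit of > 100000 nM in this assay, at which 1 of the 3 values shown sits, and (the limit of > 200000 nM in this assay, at which 1 of the 3 values shown sits).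

Compound 3 `CC1Oc2ccc(Br)cc2C=C1/C=C1\SC(=O)N(C)C1=O` rests on a different core; how its core differs from the core of compound 1 is not broken down here. In this assay compound 3 gives > 50000 nM, which is also a limit of the assay, (the limit of > 50000 nM in this assay, at which 1 of the 3 values shown sits).

Compound 4 `CCN1C(=O)S/C(=C\C2=Cc3cc(Br)ccc3OC2C)C1=O` has not yet been measured. Within the data shown here, it differs from compound 3 by methyl in place of hydrogen on a saturated chain carbon bound to an amide-type nitrogen in a ring, the same change as the one from compound 1 to compound 2, made at the same place. The earlier instance gives no readable size, so no size is carried over from it. The step from compound 3 to compound 4 in this assay is expected to be a step that the limit leaves unreadable from compound 3 to compound 4. That expectation rests on compound 3, whose value > 50000 nM is a limit, and on the change being a single methyl entering. Compound 4 is expected to give 100000 nM in this assay, between 30000 nM and 300000 nM, and most likely to be reported only as a limit.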

Compound 4, half-maximal inhibitory concentration: > 100000 nM
Compound 4: no number, only a limit; the forecaster's own chance of this, stated with the estimate: 85%; the middle value sits exactly at the limit.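

In this assay compound 4 gives > 100000 nM, which is a limit of the assay and not a number. Compound 3 also stands at a limit, and the step from compound 3 to compound 4 cannot be read in size. All four compounds shown sit at limits, and they leave open how far, if at all, methyl in place of hydrogen at this place changes antiproliferative activity.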